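A few compounds are considered here, and "the series" means these few. Any claim that something is new, unique, unknown or untested is made for them only; others in the source may bear on it.

Measured so far:
Compound 1 `CCOC1=C(/C(C)=N/OCC(=O)Nc2ccc(F)c(Cl)c2)N(C)S(=O)(=O)c2ccccc21`: in a functional assay on THP-1 cells (Homo sapiens) for inhibition, read by ELISA, with stated times of 2 h and 48 h (a higher number here means a weaker inhibitor, a lower number a stronger inhibitor), compound 1 gives > 20000 nM, which is a limit of the assay.
Compound 2 `CCOC1=C(/C(C)=N/OCC(=O)Nc2c(F)cccc2F)N(C)S(=O)(=O)c2ccccc21`: in this assay compound 2 gives > 20000 nM, again a limit.
Compound 3 `C/C(=N\OCC(=O)Nc1ccc(F)c(Cl)c1)C1=C(O)c2ccccc2S(=O)(=O)N1C`: in this assay compound 3 gives > 20000 nM, also a limit.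

All three sit at the limit of > 20000 nM in this assay, at which 3 of the 3 values shown sit, so no number is known for any of them.

The change from compound 1 to compound 2 is 2,6-difluorophenyl in place of 3-chloro-4-fluorophenyl on an amide-type nitrogen. Its step, a step that the two limits leave unreadable from compound 1 to compound 2, cannot be sized, since both ends are limits.

The two cores differ as hydrogen in place of ethyl on an oxygen on an unsaturated carbon, with step that the two limits leave unreadable from compound 1 to compound 3, likewise unreadable.

Not yet measured: compound 4 `C/C(=N\OCC(=O)Nc1c(F)cccc1F)C1=C(O)c2ccccc2S(=O)(=O)N1C`. It differs from compound 3 by 2,6-difluorophenyl in place of 3-chloro-4-fluorophenyl on an amide-type nitrogen; the place line is the same word for word as in the earlier change, so this is the same change on the core of compound 3.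

In this assay the step expected from compound 3 to compound 4 is a step that the limit leaves unreadable from compound 3 to compound 4, resting only on the fact that compound 1 and compound 2 both sit at the limit. Compound 4 is therefore expected to give about 30000 nM, within 15000 nM to 100000 nM, most likely again reported as a limit.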

Compound 4, half-maximal inhibitory concentration: > 20000 nM
Compound 4: only a limit was reported; the forecaster's own chance of this, stated with the estimate: 85%; the middle value lies beyond the limit too.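

In this assay compound 4 gives > 20000 nM, which is a limit. No step from compound 2 or compound 3 to compound 4 can be read: the limit of > 20000 nM in this assay, at which 4 of the 4 values shown sit.

The compounds shown leave open what any of the four actually gives in this assay, and whether either the 2,6-difluorophenyl change or the hydrogen-for-ethyl change alters inhibition at all.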